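The source may report more compounds than this note shows. Statements on the series, on what has been measured and on what is new or still open speak of the compounds shown alone.

Measured in an ADME assay on MCF7 cells (Homo sapiens) for cytotoxicity, with a stated time of 72 h; on this read-out lower numbers stand for stronger inhibition and higher numbers for weaker inhibition:
Compound 1 `Oc1ccccc1CNc1ncnc2c1ncn2C1CCCO1` gives > 100000 nM, a limit of the assay.
Compound 2 `COc1ccccc1CNc1ncnc2c1ncn2C1CCCO1` gives > 100000 nM, likewise a limit.
Compound 3 `COc1ccc(CNc2ncnc3c2ncn3C2CCCO2)cc1OC` gives > 100000 nM, again a limit.

Compound 2 and compound 1 differ by hydrogen in place of methyl on an oxygen on an aromatic ring. The resulting step, a step that the two limits leave unreadable from compound 2 to compound 1, has no readable size because of the limit of > 100000 nM in this assay, at which 3 of the 3 values shown sit. Compound 2 and compound 3 differ in their cores, and that difference is not broken down here. Compound 4 `COc1cc(CNc2ncnc3c2ncn3C2CCCO2)ccc1O` is not yet measured; it arises from compound 3 by the same change, (hydrogen in place of methyl on an oxygen on an aromatic ring). All three measured values sit at a limit (the limit of > 100000 nM in this assay, at which 3 of the 3 values shown sit), so the earlier step offers no size to lean on. In this assay the expected step is a step that the limit leaves unreadable from compound 3 to compound 4, resting only on the limit of > 100000 nM in this assay, at which 3 of the 3 values shown sit, at which compound 3 sits. Compound 4 is accordingly estimated at 150000 nM, most probably reported only as a limit once more.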

Compound 4, half-maximal inhibitory concentration: > 100000 nM
Compound 4 ended at the assay's limit; the forecaster's own chance of this, stated with the estimate: 85%; the middle value is on the limit's open side.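

No size can be read for the change from compound 3 to compound 4, as both results are limits: the limit of > 100000 nM in this assay, at which 4 of the 4 values shown sit.

The compounds shown leave open whether swapping methyl for hydrogen on that oxygen alters the read-out at all, and what any compound's actual value is.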